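The source may report more compounds than this note shows. Statements on the series, on what has been measured and on what is new or still open speak of the compounds shown alone.

Compound 1 `Cc1oc(-c2ccc(Cl)c(Cl)c2)nc1CN1CCC(C(=O)NCCCN2C[C@H](C)C[C@H](C)C2)CC1`: 522 10^-6 cm/s
Compound 2 `Cc1ccccc1-c1nc(CN2CCC(C(=O)NCCCN3CC4CCCC(C4)C3)CC2)c(C)o1`: 331 10^-6 cm/s
Compound 3 `Cc1ccccc1-c1nc(CN2CCC(C(=O)NCCCCN3C[C@H](C)C[C@H](C)C3)CC2)c(C)o1`: 288 10^-6 cm/s

Of the compounds shown here, three sharing one core have been measured in a physicochemical assay for permeability, using PAMPA; a lower number here means that the compound crosses the layer more slowly, a higher number that the compound crosses the layer faster. Compound 1 gives 522 10^-6 cm/s, compound 2 gives 331 10^-6 cm/s, and compound 3 gives 288 10^-6 cm/s. The gaps from compound 1 to compound 2 and to compound 3 are both within the usual scatter of this assay, so the three numbers cannot be told apart with confidence.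

The unmeasured compound 4 `Cc1ccc(-c2nc(CN3CCC(C(=O)NCCCN4C[C@H](C)C[C@H](C)C4)CC3)c(C)o2)c(C)c1` differs from compound 1 at the aromatic ring attached to the core: 2,4-dimethylphenyl in place of 3,4-dichlorophenyl on an aromatic carbon

Among the compounds with values here, only one measured step changes a single place: a 1.1-fold lower number from compound 2 to compound 3 (0.06 log units; within the scatter). That step swaps a group on the saturated chain, far from the aromatic ring, and is within the scatter. Within the data shown here, no measured step touches the ring that changes from compound 1 to compound 4, so there is no direct precedent. Among the measured compounds shown here, since the one step that is known, a 1.1-fold lower number from compound 2 to compound 3 (0.06 log units; within the scatter), stayed within the scatter, and since no change anywhere in this set has moved this assay beyond it, compound 4 is expected to stay close to compound 1, with a 1.2-fold lower number from compound 1 to compound 4 (0.06 log units; within the scatter) estimated as no step beyond the scatter. Compound 4 is therefore estimated at 450 10^-6 cm/s, with a range from 250 10^-6 cm/s to 800 10^-6 cm/s.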

Compound 4, apparent permeability: 353 10^-6 cm/s
Estimate against measurement, compound 4: 1.3-fold (0.11 log units) above; the range from low to high includes it.
By their numbers in this assay, from the lowest: compounds 3, 2, 4 and 1 (each within the scatter of the next).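

In this assay, within the data shown here, placing 2,4-dimethylphenyl where 3,4-dichlorophenyl stood on the aromatic carbon of the five-membered ring gives a 1.5-fold lower number from compound 1 to compound 4 (0.17 log units; within the scatter), and this is the first measured step at this position. The earlier step changed a group on the saturated chain, whereas this one shows that, for this pair of groups, each with one six-membered aromatic ring, exchanging two chlorine atoms for two methyl groups at different ring positions leaves compound 1 and compound 4 indistinguishable in this read-out. No measurement shown here offers an explanation for this result.

Going by these compounds, one pair of substituted phenyl groups says little about the position as a whole, so it remains open whether a phenyl ring carrying a carboxylic acid or an amine would take this assay beyond the scatter. On these data alone, it is also open whether the same exchange of 3,4-dichlorophenyl for 2,4-dimethylphenyl would again stay within the scatter with a different group at the far end of the chain.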